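Ester variation on the shared core: ring swap at the carbonyl

A few compounds are considered here, and "the series" means these few. Any claim that something is new, unique, unknown or untested is made for them only; others in the source may bear on it.

Compound 1 `CC1=CC[C@H]2[C@H](CC[C@]2(C)O)C(C)(C)[C@@H]1CC[C@H]1[C@]2(C)CC[C@H](OC(=O)c3ccccc3)C(C)(C)O[C@H]2CC[C@@]1(C)O` gives 16100 nM in a functional assay on MDA-MB-231 cells (Homo sapiens) for antiproliferative activity, read by MTT assay, with a stated time of 72 h; a lower number here means a stronger inhibitor, a higher number a weaker inhibitor. Compound 2 `CC1=CC[C@H]2[C@H](CC[C@]2(C)O)C(C)(C)[C@@H]1CC[C@H]1[C@]2(C)CC[C@H](OC(=O)NS(=O)(=O)c3ccc(C)cc3)C(C)(C)O[C@H]2CC[C@@]1(C)O` gives 47100 nM, and compound 3 `CC1=CC[C@H]2[C@H](CC[C@]2(C)O)C(C)(C)[C@@H]1CC[C@H]1[C@]2(C)CC[C@H](OC(=O)c3cccc([N+](=O)[O-])c3)C(C)(C)O[C@H]2CC[C@@]1(C)O` gives 34700 nM in this assay. Compound 3 thus stands second highest of the three numbers: the nearest number lies within the scatter, a 1.4-fold lower number from compound 2 to compound 3 (0.13 log units; within the scatter), the furthest beyond it, a 2.2-fold higher number from compound 1 to compound 3 (0.33 log units; beyond the scatter). Compound 4 `CC1=CC[C@H]2[C@H](CC[C@]2(C)O)C(C)(C)[C@@H]1CC[C@H]1[C@]2(C)CC[C@H](OC(=O)c3ccc([N+](=O)[O-])o3)C(C)(C)O[C@H]2CC[C@@]1(C)O` carries the change (5-nitrofuran-2-yl in place of 3-nitrophenyl on a carbonyl carbon). Within the data shown here, no measured step exchanges one aromatic ring for another; the only precedents at the carbonyl carbon are a 2.9-fold higher number from compound 1 to compound 2 (0.47 log units; beyond the scatter) and a 2.2-fold higher number from compound 1 to compound 3 (0.33 log units; beyond the scatter), both modest, and all three compounds sit in a narrow band. A step of at most modest size is therefore expected for a 1.0-fold higher number from compound 3 to compound 4 (0.00 log units; within the scatter), its direction uncertain. Compound 4 is expected near 35000 nM, within 15000 nM to 80000 nM.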

Compound 4, half-maximal inhibitory concentration: 11100 nM
Compound 4: middle estimate off by 3.2-fold (0.50 log units), on the high side; the measured number lies below the stated range.
By their numbers in this assay, from the lowest: compounds 4 and 1 (each within the scatter of the next); then compounds 3 and 2 (each within the scatter of the next).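

In this assay, swapping one aromatic ring for another at the carbonyl carbon moves the number: 5-nitrofuran-2-yl in place of 3-nitrophenyl gives a 3.1-fold lower number from compound 3 to compound 4 (0.50 log units; beyond the scatter), so a nitro-bearing ring does not by itself set the value at this position. The same group gives a 4.2-fold lower number from compound 2 to compound 4 (0.63 log units; beyond the scatter), while a 1.5-fold lower number from compound 1 to compound 4 (0.16 log units; within the scatter) leaves compound 1 and compound 4 indistinguishable. No measured evidence bearing on this result is available.

Open, going by these compounds, is how a furan-2-yl ester without the nitro group would read. An aminophenyl ester or a plain acetyl ester would also test whether any aromatic ring is needed here.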